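This account rests on a few compounds, and the source may have more. Where it says the series, first, only, none or still open, it means among the compounds named here.

Compound 1 `Oc1ccc(-c2cc(-c3cccs3)cc(-c3ccc(O)cc3)n2)cc1`: 11700 nM
Compound 2 `Oc1ccc(-c2cc(-c3ccsc3)cc(-c3ccccc3O)n2)cc1`: > 50000 nM
Compound 3 `Oc1ccc(-c2cc(-c3ccsc3)cc(-c3cccc(O)c3)n2)cc1`: 760 nM

Of the compounds shown here, three have been measured in a functional assay on T47D cells (Homo sapiens) for cytotoxicity, read by CCK-8 assay; a lower number here means a stronger inhibitor, a higher number a weaker inhibitor. Compound 1 gives 11700 nM. Compound 2 gives only a limit of the assay, > 50000 nM, so no number is known for it; (the limit of > 50000 nM in this assay, at which 1 of the 3 values shown sits). Compound 3 gives 760 nM in this assay, the lowest of the two numbers shown, and the nearest number, that of compound 1, lies beyond the scatter above it.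

Compound 4 `Oc1ccc(-c2cc(-c3ccsc3)cc(-c3ccc(O)cc3)n2)cc1` differs from compound 3 in one place: 4-hydroxyphenyl in place of 3-hydroxyphenyl on an aromatic carbon. Going by the values given here, only one measured step touches the hydroxyphenyl group on that carbon, an at least 65-fold lower number from compound 2 to compound 3 (1.81 log units; beyond the scatter), a large step. It does not tell the direction for the present change, but compound 1, which also carries a 4-hydroxyphenyl group there, gives 11700 nM. A higher number is therefore expected for compound 4 in this assay, estimated at 8000 nM, between 1500 nM and 40000 nM. This estimate means a step of an 11-fold higher number from compound 3 to compound 4 (1.02 log units; beyond the scatter).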

Compound 4, half-maximal inhibitory concentration: 1770 nM
Compound 4: middle estimate off by 4.5-fold (0.66 log units), on the high side; measured number inside the range.
By their numbers in this assay, from the lowest: compound 3; then compound 4; then compound 1. At a limit, above all of these: compound 2.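

In this assay, the aromatic carbon next to the ring nitrogen now shows all three hydroxyphenyl groups with thiophen-3-yl held constant: 4-hydroxyphenyl in place of 3-hydroxyphenyl gives only a 2.3-fold higher number from compound 3 to compound 4 (0.37 log units; beyond the scatter), whereas 4-hydroxyphenyl in place of 2-hydroxyphenyl gives an at least 28-fold lower number from compound 2 to compound 4 (1.45 log units; beyond the scatter), so the 2-hydroxyphenyl group stands well apart from the other two. That second step is a bound, not an exact size, as compound 2 has only a limit of the assay: the limit of > 50000 nM in this assay, at which 1 of the 4 values shown sits. With 4-hydroxyphenyl kept, the result also brings in a second place, where thiophen-3-yl in place of thiophen-2-yl gives a 6.6-fold lower number from compound 1 to compound 4 (0.82 log units; beyond the scatter).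

Going by these compounds, whether this order of the hydroxyphenyl groups also holds with a thiophen-2-yl group stays open. So does the effect of a methoxy group, an amine or a carboxylic acid in place of the hydroxyl on that phenyl ring.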